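The source may report more compounds than this note shows. Statements on the series, on what has been measured and on what is new or still open speak of the compounds shown alone.

In a functional assay on CRL2813 cells (Homo sapiens) for cytotoxicity, read by sulforhodamine B assay, with a stated time of 5 days (a lower number here means a stronger inhibitor, a higher number a weaker inhibitor), compound 1 (`O=C(Nc1cccc(F)c1)N[C@H]1CC[C@H](Oc2ccc(F)cc2)CC1`) gives 8300 nM, and compound 2 (`O=C(Nc1cccc(C(F)(F)F)c1)N[C@H]1CC[C@@H](Oc2ccc(F)cc2)CC1`) gives 2600 nM. For the measured compounds named here, compound 1 therefore holds the higher of the only two numbers available, and its gap to compound 2 lies beyond the scatter. Going by the values given here, no pair of measured compounds differs in just one place, so no single change has a measured size yet.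

Compound 3 (`CSc1ccc(NC(=O)N[C@H]2CC[C@H](Oc3ccc(F)cc3)CC2)cc1`) is the next to be read. It carries 4-(methylsulfanyl)phenyl in place of 3-fluorophenyl on an amide-type nitrogen, with the core of compound 1 otherwise kept: 4-(methylsulfanyl)phenyl in place of 3-fluorophenyl on an amide-type nitrogen.

Among the compounds with values here, with compound 1 at 8300 nM and compound 2 at 2600 nM as the sole guides, a modest move toward a lower number is expected in this assay, although a result within the scatter of compound 1 remains quite possible. The estimated step is a 1.8-fold lower number from compound 1 to compound 3 (0.27 log units; within the scatter). For compound 3 the estimated value is 4500 nM, with an expected range of 1500 nM to 13000 nM.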

Compound 3, half-maximal inhibitory concentration: > 20000 nM
Compound 3: no number, only a limit; the forecaster's own chance of this, stated with the estimate: 10%; at least 4.4-fold (0.64 log units) between middle value and limit.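

In this assay, compound 3 returns only a limit of the assay, > 20000 nM, and not a number. Even so, the series now has its first single-place change with a measured direction: on an amide-type nitrogen whose other neighbour is the carbonyl carbon, 4-(methylsulfanyl)phenyl in place of 3-fluorophenyl gives an at least 2.4-fold higher number from compound 1 to compound 3 (0.38 log units; beyond the scatter), so the number at this position depends on the aryl group it carries, and this change moves it toward a weaker compound. The step has a minimum size but no upper end, and the reading rests on a single compound at the top of the range: the limit of > 20000 nM in this assay, at which 1 of the 3 values shown sits.

Compound 3 alters both the substituent and its place on the phenyl ring relative to compound 1, so the shift cannot be assigned to either alone, and compound 2 differs from compound 1 in more than one place and cannot settle the matter. Also open, from the compounds shown here alone, is how an amine or a carboxylic acid on that phenyl ring would read here, and whether a longer chain in place of the methyl of the methylsulfanyl group would keep compound 3 at the limit.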